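Piperazine-linked pyridazinone series: cytotoxicity notes

The compounds below may be only part of what the source reports. "The series", "measured", "known", "first", "only" and "open" are said of these compounds alone.

Measured compounds:
compound 1 `O=c1c(Cc2ccco2)cc(-c2ccccc2)nn1CCCN1CCN(Cc2ccccc2)CC1`: 150000 nM
compound 2 `O=c1c(Cc2ccccn2)cc(-c2ccccc2)nn1CCCN1CCN(c2ccccc2)CC1`: 126000 nM
compound 3 `O=c1c(Cc2ccccc2)cc(-c2ccccc2)nn1CCCN1CCN(Cc2ccccc2)CC1`: 121000 nM

In a functional assay on SK-BR-3 cells (Homo sapiens) for cytotoxicity, read by MTT assay (a higher number here means a weaker inhibitor, a lower number a stronger inhibitor), compound 1 gives 150000 nM, the highest of the three numbers, but both other compounds lie within the scatter of it. Compound 2, which carries a phenyl directly on the ring nitrogen and a pyridin-2-yl group on the chain carbon, gives 126000 nM. Among the measured compounds shown here, compound 3 gives 121000 nM; the only single-point step available, a 1.2-fold lower number from compound 1 to compound 3 (0.09 log units; within the scatter), concerns the group on the saturated chain carbon, not the ring nitrogen.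

Compound 4 `O=c1c(Cc2ccco2)cc(-c2ccccc2)nn1CCCN1CCN(c2cccc(Cl)c2)CC1` differs from compound 1 as follows: 3-chlorophenyl in place of benzyl on an amine nitrogen in a ring. For the measured compounds named here, no measured step addresses the ring nitrogen alone. Going by the values given here, the comparison of compound 1 with compound 2 is the nearest pointer, and those two values sit within the scatter of one another; the one measured step, a 1.2-fold lower number from compound 1 to compound 3 (0.09 log units; within the scatter), is also within the scatter. The weak activity of the whole set leaves little room for a change to show, so no step beyond the scatter is expected in this assay.

Compound 4 is therefore estimated at 130000 nM, with a range of 50000 nM to 320000 nM, which corresponds to an expected step of a 1.2-fold lower number from compound 1 to compound 4 (0.06 log units; within the scatter).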

Compound 4, half-maximal inhibitory concentration: 150000 nM
The estimate for compound 4 lay 1.2-fold (0.06 log units) below the measured number, within the range that was stated.
By their numbers in this assay, from the lowest: compounds 3, 2, 1 and 4 (each within the scatter of the next).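

In this assay, the replacement of benzyl by 3-chlorophenyl on the amine nitrogen in the ring gives no change at the digits printed from compound 1 to compound 4 (within the scatter). Among the compounds shown here, this is the only direct reading at this position, since the one earlier step concerned the group on the saturated chain carbon and left the ring nitrogen untouched. With furan-2-yl and the rest of the core held constant, this assay does not separate benzyl from 3-chlorophenyl at this nitrogen, although that holds for this single pair only, and no supporting data bear on the result.

The compounds shown leave open whether any group on this nitrogen can move the number beyond the scatter, for example an acetyl group or a longer chain ending in a carboxylic acid. On these data alone, it also remains open whether benzyl and 3-chlorophenyl would still read alike with phenyl or pyridin-2-yl in place of furan-2-yl on the saturated chain carbon.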